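Adding a Second Trifluoromethyl to a Semicarbazide Analogue

The compounds below may be only part of what the source reports. "The series", "measured", "known", "first", "only" and "open" are said of these compounds alone.

Three compounds sharing the same quinoline-bearing amine and a urea-type linker were tested in a functional assay on HeLa cells (Homo sapiens) for inhibition, read by MTT assay, with a stated time of 72 h; on this read-out higher numbers stand for weaker inhibition and lower numbers for stronger inhibition. Compound 1 `COc1cc(NC(C)CCCNC(=O)Nc2cc(C(F)(F)F)cc(C(F)(F)F)c2)c2ncccc2c1` gives 3100 nM. Compound 2 `COc1cc(NC(C)CCCNC(=O)Nc2cccc(C(F)(F)F)c2)c2ncccc2c1` gives 14000 nM. Compound 3 `COc1cc(NC(C)CCCNC(=O)NNC(=O)Nc2cccc(C(F)(F)F)c2)c2ncccc2c1` gives 4900 nM. Compound 1 and compound 2 differ by a single change, (trifluoromethyl in place of hydrogen on an aromatic carbon), and the step is a 4.5-fold lower number from compound 2 to compound 1 (0.65 log units; beyond the scatter). Compound 3 carries a longer linker than compound 2; the difference between the two cores is not broken down here, and the two values alone show compound 3 with the lower number. Compound 3 and compound 1 lie within the scatter of each other, so no order is drawn between them.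

The unmeasured compound 4 `COc1cc(NC(C)CCCNC(=O)NNC(=O)Nc2cc(C(F)(F)F)cc(C(F)(F)F)c2)c2ncccc2c1` stands to compound 3 exactly as compound 1 stands to compound 2: the change is trifluoromethyl in place of hydrogen on an aromatic carbon, and the place it occupies is described in the same terms in both pairs, so it is the same change. Its effect is known only from compound 2 and compound 1, where it gave a 4.5-fold lower number from compound 2 to compound 1 (0.65 log units; beyond the scatter). The expectation for compound 4 in this assay rests on that one step; because the same change on compound 2 gave a 4.5-fold lower number from compound 2 to compound 1 (0.65 log units; beyond the scatter), a step of a 4.1-fold lower number from compound 3 to compound 4 (0.61 log units; beyond the scatter) is expected here. Compound 4 is therefore estimated at 1200 nM, with a range from 400 nM to 4000 nM.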

Compound 4, half-maximal inhibitory concentration: 17000 nM
The estimate for compound 4 lay 14-fold (1.15 log units) below the measured number, outside the stated range (above it).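

In this assay the added trifluoromethyl did not repeat on the core with the longer linker what it had done on the core of compound 2, and the result went the other way, with a 3.5-fold higher number from compound 3 to compound 4 (0.54 log units; beyond the scatter). Set side by side, the two results disagree in direction, so in this series the step seen on one core cannot be carried over as a forecast for the other: the same change on two cores in this assay, a 4.5-fold lower number (0.65 log units; beyond the scatter) from compound 2 to compound 1 and a 3.5-fold higher number (0.54 log units; beyond the scatter) from compound 3 to compound 4, 16-fold (1.20 log units) apart, beyond the scatter of two such steps This shows that the effect of the change depends on the core it is made on, but it rests on only two pairs in a single assay, and it does not show which feature of the two cores reverses the step, nor whether a reversal would occur on any further core.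

The compounds shown leave open whether other groups on that aromatic carbon, such as a chlorine, a nitrile or a methoxy group, would also give steps of opposite direction on the two cores or would behave alike on both. They also leave open how the step would run on a linker of another kind, such as a longer alkyl chain or one carrying an amine.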